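Dropping the chloro substituent from compound 2

This account rests on a few compounds, and the source may have more. Where it says the series, first, only, none or still open, it means among the compounds named here.

Measured so far:
- compound 1 `O=c1cc(CSC(=S)N2CCCCC2)oc2ccccc12`: in a functional assay on MDA-MB-435S cells (Homo sapiens) for antiproliferative activity, read by MTT assay, with a stated time of 72 h (a lower number here means a stronger inhibitor, a higher number a weaker inhibitor), compound 1 gives > 25000 nM, which is a limit of the assay and not a number.
- compound 2 `CC(C)N(C(=S)SCc1cc(=O)c2ccc(Cl)cc2o1)C(C)C`: in this assay compound 2 gives > 25000 nM, again a limit of the assay rather than a number.

Compound 2 therefore stands at the edge of what this assay reports, and it is not alone there: the limit of > 25000 nM in this assay, at which 2 of the 2 values shown sit. Among the measured compounds shown here, nothing in the two results separates compound 1 from compound 2, and no step between measured compounds is available to calibrate what a single change does.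

Compound 3 `CC(C)N(C(=S)SCc1cc(=O)c2ccccc2o1)C(C)C` differs from compound 2 in one place only: hydrogen in place of chloro on an aromatic carbon. For the measured compounds named here, with both measured compounds sitting at the limit, there is no measured step to lean on, and the expectation for this change is no movement beyond the scatter; the step from compound 2 to compound 3 is estimated as a step that the limit leaves unreadable from compound 2 to compound 3. Compound 3 is accordingly expected to give about 30000 nM in this assay, within a range of 10000 nM to 100000 nM, most likely reported again as a limit.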

Compound 3, half-maximal inhibitory concentration: > 40000 nM
Compound 3 was reported as a limit (the forecaster's own chance of this, stated with the estimate: 85%); middle value at least 1.3-fold (0.12 log units) from the limit.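

In this assay compound 3 gives > 40000 nM, again a limit of the assay and not a number. Neither the step from compound 2 to compound 3 nor the step from compound 1 to compound 3 can be read. The compounds shown leave open whether either change, chloro to hydrogen or piperidin-1-yl to diisopropylamino, alters antiproliferative activity at all.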